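Substituent swaps at the aryl position in the benzyl amide series

The source may report more compounds than this note shows. Statements on the series, on what has been measured and on what is new or still open speak of the compounds shown alone.

Compound 1 `CCC1CCN(c2cc(C(F)(F)F)ccc2CNC(=O)C(C)c2ccc(NS(C)(=O)=O)c(F)c2)CC1` and compound 2 `CC(C(=O)NCc1ccc(C(F)(F)F)cc1SCc1ccco1)c1ccc(NS(C)(=O)=O)c(F)c1` share the amide core and differ only in the group on the aromatic carbon ortho to the benzylic amide and meta to the trifluoromethyl group. In an assay on CHO cells for antagonist activity at transient receptor potential cation channel subfamily V member 1 (Homo sapiens), read by FLIPR (on this read-out lower numbers stand for stronger inhibition and higher numbers for weaker inhibition), compound 1 gives 0.7 nM, and compound 2 gives 3.2 nM. For the measured compounds named here, compound 2 thus holds the higher of the two numbers so far, with compound 1 the nearest measured neighbour; the only measured step at this position, a 4.6-fold higher number from compound 1 to compound 2 (0.66 log units; beyond the scatter), is modest. Compound 3 `CC(C(=O)NCc1ccc(C(F)(F)F)cc1-c1cccc(F)c1)c1ccc(NS(C)(=O)=O)c(F)c1` continues at the same site: 3-fluorophenyl in place of ((furan-2-yl)methyl)sulfanyl on an aromatic carbon. Going by the values given here, no measured pair shows an aryl group entering at this carbon, so the expectation rests on the one step available, which indicates that the position accepts a different group of similar size with only a modest shift in the number. On that basis compound 3 is expected to sit close to compound 2, with the estimated change a 1.1-fold higher number from compound 2 to compound 3 (0.04 log units; within the scatter) not clearly beyond the scatter. The estimate for compound 3 in this assay is 3.5 nM, within a range of 0.8 nM to 15 nM.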

Compound 3, inhibition constant: 1.9 nM
Estimate against measurement, compound 3: 1.8-fold (0.27 log units) above, within the range that was stated.
By their numbers in this assay, from the lowest: compound 1; then compounds 3 and 2 (each within the scatter of the next).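

At this aromatic carbon, 3-fluorophenyl and ((furan-2-yl)methyl)sulfanyl cannot be told apart in this assay: a 1.7-fold lower number from compound 2 to compound 3 (0.23 log units; within the scatter) is within the scatter, even though the two groups differ in ring type and in hydrogen-bond acceptors, with the count falling to zero in the entering group. Compound 3 also shows that a directly attached carbocyclic aromatic ring is accepted here, while 4-ethylpiperidin-1-yl still gives the lowest number of the three, with a 2.7-fold higher number from compound 1 to compound 3 (0.43 log units; beyond the scatter) being a modest step beyond the scatter that matches the direction of the step to compound 2. No measurement available here explains either the similarity of compounds 2 and 3 or the separation of compound 1 from them.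

From the compounds shown here alone, it remains open whether the edge held by compound 1 depends on the ring nitrogen, on the ethyl group or on the saturated ring, a question that piperidin-1-yl, diethylamino or cyclohexyl at this carbon would address. Also open, going by these compounds, is how this position responds to a carboxylic acid, a primary amine or a longer alkyl chain, and whether moving the fluorine around the phenyl ring changes the number at all.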